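A few compounds are considered here, and "the series" means these few. Any claim that something is new, unique, unknown or untested is made for them only; others in the source may bear on it.

Compound 1 `C#CCSc1nc(Nc2ccccc2Cl)c2ccncc2n1` gives 17200 nM in a functional assay on HepG2 cells (Homo sapiens) for inhibition, read by MTT assay, with a stated time of 72 h; a higher number here means a weaker inhibitor, a lower number a stronger inhibitor.
Compound 2 `C#CCSc1nc(Nc2ccccc2OC)c2ccncc2n1` gives 4530 nM in this assay.

For the measured compounds named here, compound 2 holds the lower of these two numbers; the only measured step, a 3.8-fold lower number from compound 1 to compound 2 (0.58 log units; beyond the scatter), is a change on the aromatic ring that carries the amine. Compound 3 `C#CCSc1nc(Nc2ccccc2O)c2ccncc2n1` differs from compound 2 by hydrogen in place of methyl on an oxygen on an aromatic ring. Going by the values given here, no measured step concerns this oxygen, so the one known step bears on it only loosely. For compound 3 in this assay the estimate is a 1.1-fold higher number from compound 2 to compound 3 (0.04 log units; within the scatter), a change not expected to go beyond the scatter. Compound 3 is therefore estimated at 5000 nM, within 1500 nM to 16000 nM.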

Compound 3, half-maximal inhibitory concentration: > 80000 nM
Compound 3 gave a limit, no number (the forecaster's own chance of this, stated with the estimate: 5%); middle value at least 16-fold (1.20 log units) away from the limit.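

Compound 3 gives no number in this assay, only a limit of the assay: the limit of > 80000 nM in this assay, at which 1 of the 3 values shown sits.
Going from methoxy to hydroxy brings an at least 17-fold higher number from compound 2 to compound 3 (1.24 log units; beyond the scatter) and going from chloro to hydroxy brings an at least 4.6-fold higher number from compound 1 to compound 3 (0.66 log units; beyond the scatter) on the same aromatic carbon. Of the three groups there, hydroxy thus gives the weakest result, and the methyl on that oxygen proves decisive in a way compounds 1 and 2 alone could not show.

On these data alone, whether an amine or an ethoxy group in this place would behave like hydroxy or like methoxy stays open. As far as these compounds go, the full size of both steps also stays unknown, as they rest on a limit.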